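A few compounds are considered here, and "the series" means these few. Any claim that something is new, unique, unknown or untested is made for them only; others in the source may bear on it.

Of the compounds shown here, three here share one core and have been tested in an assay for inhibition of MAP kinase-interacting serine/threonine-protein kinase 2 (Homo sapiens), read by luminescence and ADP-Glo, with a stated time of 2 h; a lower number here means a stronger inhibitor, a higher number a weaker inhibitor. Compound 1 `NC(=O)c1cccc(Cn2cc(-c3ccc4cn[nH]c4c3)ccc2=O)c1` gives 106 nM in this assay. Compound 2 `Nc1n[nH]c2cc(-c3ccc(=O)n(Cc4cccc(Cl)c4)c3)ccc12`, which carries a chlorine-bearing benzyl group and an extra amino group on its core, gives 6 nM in this assay. Compound 3 `O=C(N1CCOCC1)n1cc(-c2ccc3cn[nH]c3c2)ccc1=O` stands apart from the other two. In this assay compound 3 gives only a limit, > 2000 nM, which is not a measured number but the point beyond which the assay stops reporting. Of the three values shown, one sits at this point, as noted in the limit of > 2000 nM in this assay, at which 1 of the 3 values shown sits.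

Compound 4 `Nc1cccc(Cn2cc(-c3ccc4cn[nH]c4c3)ccc2=O)c1` has not yet been measured. It differs from compound 3 in one place: 3-aminobenzyl in place of (morpholin-4-yl)carbonyl on an aromatic nitrogen. In words, 3-aminobenzyl takes the place of (morpholin-4-yl)carbonyl on an aromatic nitrogen.

Among the measured compounds shown here, no measured pair of compounds differs in exactly this way, so the size of the step is a matter of expectation. Compound 1 carries a benzyl group on that same aromatic nitrogen and gives 106 nM in this assay, which is the nearest guide. The step from compound 3 to compound 4 is therefore expected to be a gain in potency well beyond the scatter, an at least 13-fold lower number from compound 3 to compound 4 (1.12 log units; beyond the scatter). Compound 4 is estimated at 150 nM, with a likely range from 40 nM to 600 nM.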

Compound 4, half-maximal inhibitory concentration: 84 nM
Beside the measured number, compound 4's estimate is 1.8-fold (0.25 log units) above it; low and high end bracket the measured number.
By their numbers in this assay, from the lowest: compound 2; then compounds 4 and 1 (each within the scatter of the next). At a limit, above all of these: compound 3.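

In this assay, among the compounds shown here, 3-aminobenzyl in place of (morpholin-4-yl)carbonyl on the aromatic nitrogen gives an at least 23-fold lower number from compound 3 to compound 4 (1.37 log units; beyond the scatter), the first step between two compounds that differ in one place. The true size of this step remains unknown, because compound 3 stands at a limit of the assay and not at a measured number: the limit of > 2000 nM in this assay, at which 1 of the 4 values shown sits.

The second step looks at the benzyl group itself, where amino in place of carbamoyl gives a 1.3-fold lower number from compound 1 to compound 4 (0.10 log units; within the scatter), so these two groups cannot be told apart in this assay.

Compound 2 differs from compound 4 in more than one place, so the compounds shown do not separate the part played by its chlorine from that of the amino group on its core. On these data alone, it also remains open whether a plain unsubstituted benzyl group, or a carboxylic acid or a longer amine chain in place of the amino group of compound 4, would give a number in the same range.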